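The source may report more compounds than this note shows. Statements on the series, on what has been measured and on what is new or still open speak of the compounds shown alone.

Compound 1 `CCCCCCCC(=O)OCCc1c(-c2ccccc2Cl)c2cc(Cl)ccc2[nH]c1=O` and compound 2 `CC(=O)N1CCC(C(=O)OCCc2c(-c3ccccc3Cl)c3cc(Cl)ccc3[nH]c2=O)CC1` share a core that carries an ester-linked side chain, and both have been tested in an ADME assay on HepG2 2.2.15 cells (Homo sapiens) for cytotoxicity; on this read-out lower numbers stand for higher toxicity in this test and higher numbers for lower toxicity in this test. In this assay compound 1 gives 78000 nM, the lowest of the two numbers seen so far, and compound 2 gives 82000 nM. Within the data shown here, the only measured step, a 1.1-fold higher number from compound 1 to compound 2 (0.02 log units; within the scatter), replaces the heptyl on the carbonyl carbon with 1-acetylpiperidin-4-yl and leaves the read-out essentially unchanged.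

Compound 3 `COc1ccc(/C=C/C(=O)OCCc2c(-c3ccccc3Cl)c3cc(Cl)ccc3[nH]c2=O)cc1` is the next member of the set. It differs from compound 1 in the same position: 2-(4-methoxyphenyl)ethenyl in place of heptyl on a carbonyl carbon. Among the measured compounds shown here, the one step that bears on this change, the one from compound 1 to compound 2, is within the scatter, so the side chain on the carbonyl carbon has so far not moved the read-out. On that basis the expected step of a 1.1-fold lower number from compound 1 to compound 3 (0.05 log units; within the scatter) for compound 3 is none beyond the scatter. Compound 3 is therefore estimated at 70000 nM, with a range from 30000 nM to 150000 nM.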

Compound 3, half-maximal cytotoxic concentration: > 1200000 nM
Compound 3: only a limit was reported; the forecaster's own chance of this, stated with the estimate: 20%; middle value at least 17-fold (1.23 log units) from the limit.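

In this assay the group on the carbonyl carbon turns out to be able to move the read-out: 2-(4-methoxyphenyl)ethenyl gives an at least 15-fold higher number from compound 1 to compound 3 (1.18 log units; beyond the scatter) when it replaces heptyl and an at least 14-fold higher number from compound 2 to compound 3 (1.16 log units; beyond the scatter) when it replaces 1-acetylpiperidin-4-yl. The earlier pair gave no sign of this, so the flat result for heptyl and 1-acetylpiperidin-4-yl does not hold for every group at this place, and among these three side chains only the one with a six-membered aromatic ring of carbon stands apart. The value of compound 3 is a limit of the assay and not a number: the limit of > 1200000 nM in this assay, at which 1 of the 3 values shown sits.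

The compounds shown leave open which part of the new group goes with the step, the aromatic ring, the double bond outside it or the methoxy group, and a plain 2-phenylethenyl or a saturated 2-(4-methoxyphenyl)ethyl on the same carbonyl carbon would separate these. They also leave open how a side chain ending in an amine or a carboxylic acid would read here.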